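Alanyl-to-prolyl swap on the sulfamoyl adenosine series

This account rests on a few compounds, and the source may have more. Where it says the series, first, only, none or still open, it means among the compounds named here.

Measured so far:
- compound 1, `C[C@H](N)C(=O)NS(=O)(=O)OC[C@H]1OC[C@@H](n2cnc3c(N)ncnc32)[C@H](O)[C@@H]1O`: 300 nM
- compound 2, `C[C@H](N)C(=O)NS(=O)(=O)OC[C@H]1OC[C@@H](n2cnc3c(N)ncnc32)C[C@@H]1O`: 5500 nM

Among the compounds with values here, in a functional assay on PBMC cells (Homo sapiens) for inhibition (on this read-out higher numbers stand for weaker inhibition and lower numbers for stronger inhibition), compound 1 gives the lowest of the two numbers so far; the nearest is compound 2, reached by an 18-fold higher number from compound 1 to compound 2 (1.26 log units; beyond the scatter), a single change of hydrogen in place of hydroxy on a saturated ring carbon.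

Compound 3, `Nc1ncnc2c1ncn2[C@@H]1CO[C@H](COS(=O)(=O)NC(=O)[C@@H]2CCCN2)[C@@H](O)[C@H]1O`, is not yet measured. Its difference from compound 1 is pyrrolidin-2-yl in place of 1-aminoethyl on a carbonyl carbon. Within the data shown here, no measured step touches the acyl side chain; the one step known concerns the sugar ring, so it does not bear on this change directly. With nothing to anchor it, the expectation for this step in this assay is uncertain: a move of moderate size toward a higher number, a 3.3-fold higher number from compound 1 to compound 3 (0.52 log units; beyond the scatter), is taken as the working guess. Compound 3 is therefore estimated at 1000 nM, with a range from 100 nM to 10000 nM.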

Compound 3, half-maximal inhibitory concentration: 750 nM
Compound 3: middle estimate off by 1.3-fold (0.12 log units), on the high side; measured number inside the range.
By their numbers in this assay, from the lowest: compound 1; then compound 3; then compound 2.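

In this assay the group on the carbonyl carbon now has its first reading: pyrrolidin-2-yl in place of 1-aminoethyl gives a 2.5-fold higher number from compound 1 to compound 3 (0.40 log units; beyond the scatter) and counts as a modest step. Compound 3 therefore keeps measurable inhibition with the side chain closed into a five-membered non-aromatic ring, while hydrogen in place of hydroxy on a saturated ring carbon remains the large step, with an 18-fold higher number from compound 1 to compound 2 (1.26 log units; beyond the scatter) in the same read-out. No available data explain either step, so the result records a size and no cause.

On these data alone, whether other groups on the carbonyl carbon, such as a piperidin-2-yl ring, a longer chain or a carboxylic acid, would keep or lose inhibition stays open. Also open, as far as these compounds go, is how pyrrolidin-2-yl behaves when combined with hydrogen in place of hydroxy on the saturated ring carbon.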